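Trimming the Amide of Compound 2

The source may report more compounds than this note shows. Statements on the series, on what has been measured and on what is new or still open speak of the compounds shown alone.

Compound 2 `COc1ccc(-c2cnc(NC(=O)c3ccc(O)cc3)n2C)cc1` stands at the limit of a toxicity assay on THP-1 cells (Homo sapiens) for inhibition; a higher number here means that more compound is tolerated, a lower number that less compound is tolerated: its value of > 100000 nM is a limit of the assay and not a number. Compound 1 `CCCn1c(-c2ccc(OC)cc2)cnc1NC(=O)c1ccc(F)cc1` likewise reaches a limit there, at > 100000 nM. Compound 3 `O=C(Nc1ncc(-c2ccccc2)o1)c1ccc(F)cc1` gives a number in this assay, 17000 nM. Two of the three values thus rest at the limit of > 100000 nM in this assay, at which 2 of the 3 values shown sit. Compound 4 `COc1ccc(-c2cnc(NC(C)=O)n2C)cc1` is not yet measured; it differs from compound 2 by methyl in place of 4-hydroxyphenyl on a carbonyl carbon. Among the measured compounds shown here, no step between measured compounds is known, so for this change no size beyond the scatter is expected in this assay, and the step of a number no higher from compound 2 to compound 4 (the limit leaves the size open) is estimated as flat. Compound 4 is expected to give about 100000 nM, within 30000 nM to 300000 nM.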

Compound 4, half-maximal cytotoxic concentration: > 100000 nM
Compound 4 was reported as a limit; the forecaster's own chance of this, stated with the estimate: 70%; the middle value lies on the limit itself.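

In this assay compound 4 gives > 100000 nM, a limit and not a number. Among the compounds shown here, compound 2 also stands at a limit, so no step between compound 2 and compound 4 can be read. The compounds shown leave open what methyl in place of 4-hydroxyphenyl does in this assay.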